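This account rests on a few compounds, and the source may have more. Where it says the series, first, only, none or still open, it means among the compounds named here.

Working notes on the series. Compound 3 `C[C@H](NC(=O)c1c(-c2ccccc2)nnn1CCOc1ccc(F)cc1)c1ccc(C(=O)O)cc1` gives 3.1 nM in a functional assay on CHO cells for antagonist activity at prostaglandin E2 receptor EP4 subtype (Homo sapiens), read by calcium flux, with a stated time of 15 min (a lower number here means a stronger inhibitor, a higher number a weaker inhibitor), the lowest of the three numbers measured. Compound 2 `COc1ccc(Cn2nnc(-c3ccccc3)c2C(=O)N[C@@H](C)c2ccc(C(=O)O)cc2)cc1F` gives 29.8 nM and compound 1 `C[C@H](NC(=O)c1c(-c2ccccc2)nnn1Cc1ccc(F)c(F)c1)c1ccc(C(=O)O)cc1` gives 148 nM; the steps read a 5.0-fold lower number from compound 1 to compound 2 (0.70 log units; beyond the scatter), a 48-fold lower number from compound 1 to compound 3 (1.68 log units; beyond the scatter) and a 9.6-fold lower number from compound 2 to compound 3 (0.98 log units; beyond the scatter). Compound 4 `C[C@H](NC(=O)c1c(-c2ccccc2)nnn1CCOc1ccc(C(F)(F)F)cc1)c1ccc(C(=O)O)cc1` differs from compound 3 by trifluoromethyl in place of fluoro on an aromatic carbon. Going by the values given here, no measured step alters a substituent on the phenoxy ring; the only aromatic-substituent swap on record, a 5.0-fold lower number from compound 1 to compound 2 (0.70 log units; beyond the scatter), was modest and sat on a different arm, and the large steps came from exchanging that arm. The step of a 1.5-fold higher number from compound 3 to compound 4 (0.16 log units; within the scatter) is therefore expected to be small, within or near the scatter. Compound 4 is estimated at 4.5 nM, with a range from 1.5 nM to 14 nM.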

Compound 4, half-maximal inhibitory concentration: 49.1 nM
Compound 4: middle estimate off by 11-fold (1.04 log units), on the low side; measured number outside the range, above it.
By their numbers in this assay, from the lowest: compound 3; then compounds 2 and 4 (each within the scatter of the next); then compound 1.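

On the phenoxy ring, a substituent swap moves the number as much as exchanges of the whole arm do: a 16-fold higher number from compound 3 to compound 4 (1.20 log units; beyond the scatter) in this assay with trifluoromethyl in place of fluoro. The advantage of the phenoxy arm therefore depends on this substituent: a 3.0-fold lower number from compound 1 to compound 4 (0.48 log units; beyond the scatter) compares with a 48-fold lower number from compound 1 to compound 3 (1.68 log units; beyond the scatter) for the fluoro analogue, while a 1.6-fold higher number from compound 2 to compound 4 (0.22 log units; within the scatter) leaves no separation from the 3-fluoro-4-methoxyphenyl arm. No available evidence bears on this loss.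

As far as these compounds go, what hydrogen, chloro, methyl or methoxy would give at this aromatic carbon remains open. So does whether a longer chain to the phenoxy ring would change the step.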